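Fluorine for Trifluoromethyl on a Shared Core

This account rests on a few compounds, and the source may have more. Where it says the series, first, only, none or still open, it means among the compounds named here.

In a functional assay on PC-3 cells (Homo sapiens) for antiproliferative activity, read by MTT assay, tested at 5 uM (on this read-out higher numbers stand for a stronger effect at the one concentration tested and lower numbers for a weaker effect), three compounds have been measured so far:
compound 1 `COc1cc(C2=NN(C(C)=O)C(c3cccc(OC)c3OC)O2)cc(OC)c1OC` gives 58.2%
compound 2 `COc1ccc(OC)c(C2OC(c3cc(OC)c(OC)c(OC)c3)=NN2C(C)=O)c1` gives 43.2%
compound 3 `COc1cc(C2=NN(C(C)=O)C(c3ccc(C(F)(F)F)cc3)O2)cc(OC)c1OC` gives -0.7%

Compound 3 stands lowest of the three in this assay; the nearest is compound 2 and the furthest compound 1, both well beyond the scatter. Compound 4 `COc1cc(C2=NN(C(C)=O)C(c3cccc(F)c3)O2)cc(OC)c1OC` has not yet been measured. It differs from compound 3 in one place: 3-fluorophenyl in place of 4-(trifluoromethyl)phenyl on a saturated ring carbon. Among the compounds with values here, the steps that bear on this change are the two leading into compound 3: a number 58.9 percentage points lower from compound 1 to compound 3 (beyond the scatter) and a number 43.9 percentage points lower from compound 2 to compound 3 (beyond the scatter). Both show that exchanging a methoxy-bearing phenyl for the 4-(trifluoromethyl)phenyl removes almost all inhibition. Compound 4 carries a 3-fluorophenyl rather than any methoxy-bearing phenyl, so no return toward the level of compound 1 or compound 2 is expected. For compound 4 only a small rise is expected, a number 10.7 percentage points higher from compound 3 to compound 4 (beyond the scatter), much of it within the scatter. Compound 4 is therefore estimated at 10%, between -8% and 35%.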

Compound 4, a percentage reported as inhibition, at one concentration (the size of the read-out at that concentration, not a potency): 43.5%
Estimate against measurement, compound 4: 33.5 percentage points below, outside the stated range (above it).
By their numbers in this assay, from the lowest: compound 3; then compounds 2 and 4 (each within the scatter of the next); then compound 1.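

Replacing the 4-(trifluoromethyl)phenyl with a 3-fluorophenyl gives a number 44.2 percentage points higher from compound 3 to compound 4 (beyond the scatter) in this assay, so a methoxy-bearing phenyl is not required on this saturated ring carbon. Measured against the two dimethoxyphenyl compounds, the 3-fluorophenyl gives a number 0.3 percentage points higher from compound 2 to compound 4 (within the scatter) and a number 14.7 percentage points lower from compound 1 to compound 4 (beyond the scatter), so it matches the 2,5-dimethoxyphenyl while the 2,3-dimethoxyphenyl stays ahead. No measurement at hand explains why these phenyl groups differ.

This change alters both the group and where it sits on the phenyl ring, and the compounds shown cannot separate those two effects. On these data alone, whether an amine or a carboxylic acid on that phenyl ring would keep the inhibition also remains open.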